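The compounds below may be only part of what the source reports. "The series", "measured", "known", "first", "only" and "open" are said of these compounds alone.

Compound 1 `COc1cc2c(Oc3ccc(NC(=O)N/N=C/c4ccc(C(F)(F)F)cc4)cc3F)ccnc2cc1OCCCN1CCCCC1` gives 630 nM in a functional assay on MKN-45 cells (Homo sapiens) for cytotoxicity, read by MTT assay, with a stated time of 72 h; on this read-out lower numbers stand for stronger inhibition and higher numbers for weaker inhibition. Among the three measured compounds it shares the highest number with compound 3 `COc1cc2c(Oc3ccc(NC(=O)N/N=C/c4ccc(OC(F)(F)F)cc4)cc3F)ccnc2cc1OCCCN1CCCCC1`, which gives 630 nM; the step of no change at the digits printed from compound 1 to compound 3 (within the scatter) stays within the scatter. Compound 2 `COc1cc2c(Oc3ccc(NC(=O)N/N=C/c4ccc(F)cc4Cl)cc3F)ccnc2cc1OCCCN1CCCCC1` gives 270 nM, and the step of a 2.3-fold lower number from compound 1 to compound 2 (0.37 log units; beyond the scatter) is the only one beyond the scatter. Compound 4 `COc1cc2c(Oc3ccc(NC(=O)N/N=C/c4cc5ccccc5[nH]4)cc3F)ccnc2cc1OCCCN1CCCCC1` differs from compound 1 by 1H-indol-2-yl in place of 4-(trifluoromethyl)phenyl on a carbon with a double bond to nitrogen. Both measured steps alter this same group: one was flat, one modest. Neither introduced a hydrogen-bond donor or a five-membered aromatic ring at this place, and no step beyond the scatter is expected in either direction. Compound 4 is therefore estimated at 500 nM, within 200 nM to 1600 nM, meaning an expected step of a 1.3-fold lower number from compound 1 to compound 4 (0.10 log units; within the scatter).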

Compound 4, half-maximal inhibitory concentration: 830 nM
Estimate against measurement, compound 4: 1.7-fold (0.22 log units) below; the range from low to high includes it.
By their numbers in this assay, from the lowest: compound 2; then compounds 1, 3 and 4 (each within the scatter of the next).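

At the carbon with a double bond to nitrogen, 1H-indol-2-yl brings a five-membered aromatic ring and a hydrogen-bond donor, yet in this assay this change stays within the scatter of both single-ring groups (a 1.3-fold higher number from compound 1 to compound 4 (0.12 log units; within the scatter); a 1.3-fold higher number from compound 3 to compound 4 (0.12 log units; within the scatter)). Only 2-chloro-4-fluorophenyl stands apart from it (a 3.1-fold higher number from compound 2 to compound 4 (0.49 log units; beyond the scatter)). No evidence is available to explain these comparisons. The compounds shown leave open how an amine or a carboxylic acid on the aromatic ring at this place would compare.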